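Shrinking the Amine Ring on the Amide Nitrogen

The source may hold more compounds than are shown below. What is called first, only, known or untested is meant among the compounds shown, and "the series" means these compounds.

The series shares one core and varies the saturated amine-bearing ring attached to the amide nitrogen. Among the compounds with values here, compound 1 `Cn1cc(-c2cnc3c(-c4csc(C(=O)N[C@@H]5CCCC[C@@H]5N)c4)cnn3c2)cn1` is the first member. In an assay for inhibition of MAP/microtubule affinity-regulating kinase 3 (Homo sapiens), read by HTRF, with a stated time of 2 h (on this read-out higher numbers stand for weaker inhibition and lower numbers for stronger inhibition), compound 1 reaches only a limit of the assay, <= 0.5 nM. Within the data shown here, compound 2 `Cn1cc(-c2cnc3c(-c4csc(C(=O)N[C@@H]5CCCC[C@H]5N)c4)cnn3c2)cn1` has the same atoms and bonds, and in this assay compound 2 gives 1 nM, the only number measured so far in this set. Among the measured compounds shown here, the single measured step, an at least 2.0-fold higher number from compound 1 to compound 2 (0.30 log units; that floor lies within the scatter), is bounded only by the limit of <= 0.5 nM in this assay, at which 1 of the 2 values shown sits, and can be read in the light of the fact that compounds 1 and 2 differ only in the configuration as drawn.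

Compound 3 `Cn1cc(-c2cnc3c(-c4csc(C(=O)N[C@@H]5CCC[C@@H]5N)c4)cnn3c2)cn1` differs from compound 2 as follows: a group of 6 heavy atoms (5 carbon, 1 nitrogen; one five-membered non-aromatic ring of carbon only) in place of a group of 7 heavy atoms (6 carbon, 1 nitrogen; one six-membered non-aromatic ring of carbon only), on an amide-type nitrogen. For the measured compounds named here, no measured step involves a change of ring size, so the one measured step, which concerned configuration alone, gives only a loose guide: it suggests the shared core tolerates small changes on this ring without large movement in this assay. Compound 3 is therefore expected to sit near compound 2, with a possible slight loss, estimated at 2 nM with a range from 0.5 nM to 8 nM. This estimate means a step of a 2.0-fold higher number from compound 2 to compound 3 (0.30 log units; within the scatter), expected to lie within the scatter.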

Compound 3, half-maximal inhibitory concentration: 2 nM
Compound 3: the middle estimate sits on the measured number at the digits printed; the measured number falls inside the stated range.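

Within the data shown here, replacing 2-aminocyclohexyl with the group carrying a five-membered non-aromatic carbon ring is the first change of ring size read on the amide-type nitrogen, and in this assay it gives a 2.0-fold higher number from compound 2 to compound 3 (0.30 log units; within the scatter), so this comparison does not separate the two ring sizes. The same ring replacement, set against the other six-membered compound, gives an at least 4.0-fold higher number from compound 1 to compound 3 (0.60 log units; beyond the scatter), so the reading of the change depends on which six-membered compound serves as the reference, and those two references are related in one way only: the fact that compounds 1 and 2 differ only in the configuration as drawn This second step is a floor and not a measured size, because one end of it is a limit of the assay: the limit of <= 0.5 nM in this assay, at which 1 of the 3 values shown sits.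

The compounds shown leave open how the other drawn configurations of the five-membered ring would read in this assay, and how a four-membered carbon ring or an open aminoethyl chain on the amide-type nitrogen would compare. From the compounds shown here alone, whether a hydroxyl group could stand in place of the amine on this ring also remains open.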